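This account rests on a few compounds, and the source may have more. Where it says the series, first, only, none or still open, it means among the compounds named here.

The measured compounds and their values:

Compound 1, `CC1=C(C(=O)Nc2ccc(F)cc2)C(c2ccc([N+](=O)[O-])cc2)N=C(SCc2cccc(Cl)c2)N1`, in a functional assay on the whole organism (artery, strain albino) with Rattus norvegicus as the target, with a stated time of 15 min, at a dose of 10 mg/kg by the oral route (on this read-out lower numbers stand for less inhibition and higher numbers for more inhibition at the one dose given (going by the name of the read-out)), gives 2.1%.
Compound 2, `CC1=C(C(=O)Nc2ccc(F)cc2)C(c2ccc([N+](=O)[O-])cc2)N=C(SCc2ccc(Cl)cc2)N1`, in this assay gives 3.6%.
Compound 3, `CC1=C(C(=O)Nc2ccc(Br)cc2)C(c2ccc(Cl)cc2Cl)N=C(SCc2cccc(Cl)c2)N1`, in this assay gives 1.5%.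

All three values sit close together. Between compound 1 and compound 2 one change is made, (4-chlorophenyl in place of 3-chlorophenyl on a saturated chain carbon bound to a sulfur), and it produced a number 1.5 percentage points higher from compound 1 to compound 2 (within the scatter). The cores of compound 1 and compound 3 differ in more than one place, and that difference is not broken down here. Compound 4, `CC1=C(C(=O)Nc2ccc(Br)cc2)C(c2ccc(Cl)cc2Cl)N=C(SCc2ccc(Cl)cc2)N1`, is yet to be measured; it carries the same change relative to compound 3, namely (4-chlorophenyl in place of 3-chlorophenyl on a saturated chain carbon bound to a sulfur). For compound 4 the step is expected to be a number 1.5 percentage points higher from compound 3 to compound 4 (within the scatter), because the earlier step of a number 1.5 percentage points higher from compound 1 to compound 2 (within the scatter) was small. Compound 4 is thus estimated at 3% in this assay, likely between 0% and 10%.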

Compound 4, a percentage reported as inhibition, in the whole organism at one dose (the size of the read-out at that dose, not a potency): 4.1%
For compound 4 the middle estimate is 1.1 percentage points below the measured one; the measured number falls inside the stated range.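

Going from 3-chlorophenyl to 4-chlorophenyl on the second core gives a number 2.6 percentage points higher from compound 3 to compound 4 (within the scatter) in this assay. The change therefore looks the same on both cores: the same change on two cores in this assay, a number 1.5 percentage points higher (within the scatter) from compound 1 to compound 2 and a number 2.6 percentage points higher (within the scatter) from compound 3 to compound 4, 1.1 percentage points apart, within the scatter of two such steps. Each step on its own also lies within the scatter, so neither step shows that the change has any real effect, and two cores cannot speak for other cores in the series.

Every compound shown carries 3-chlorobenzyl or 4-chlorobenzyl on the sulfur, so it stays open how this assay responds to a different group there, such as an amine, a carboxylic acid or a longer chain. Whether any such group would move the inhibition beyond the scatter is also unknown.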